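The compounds below may be only part of what the source reports. "The series", "measured", "known", "first", "only" and "open" are said of these compounds alone.

Three compounds share one core and differ only in the short group attached to the amide-type nitrogen. Compound 1 `CCN(Cc1ccccc1C(F)(F)F)C(=O)C1CCN(S(=O)(=O)c2ccc3[nH]ncc3c2)CC1`, compound 2 `C=CCN(Cc1ccccc1C(F)(F)F)C(=O)C1CCN(S(=O)(=O)c2ccc3[nH]ncc3c2)CC1` and compound 3 `O=C(C1CCN(S(=O)(=O)c2ccc3[nH]ncc3c2)CC1)N(CCO)Cc1ccccc1C(F)(F)F` were tested in a functional assay on CHO cells for positive allosteric modulation of muscarinic acetylcholine receptor M5 (Homo sapiens), read by calcium flux; on this read-out lower numbers stand for smaller maximal responses and higher numbers for larger maximal responses. There compound 1 gives 96%, compound 2 gives 79% and compound 3 gives 60%, the lowest of the three numbers; the steps of a number 36 percentage points lower from compound 1 to compound 3 (beyond the scatter) and a number 19 percentage points lower from compound 2 to compound 3 (beyond the scatter) are both beyond the scatter. Compound 4 `O=C(C1CCN(S(=O)(=O)c2ccc3[nH]ncc3c2)CC1)N(Cc1ccccc1C(F)(F)F)CC1CC1` has not yet been measured. Its change from compound 3 is cyclopropyl in place of hydroxymethyl on a saturated chain carbon bound to an amide-type nitrogen. This removes the hydroxy group whose arrival lowered the number in a number 36 percentage points lower from compound 1 to compound 3 (beyond the scatter) and in a number 19 percentage points lower from compound 2 to compound 3 (beyond the scatter), so a rise beyond the scatter is expected, roughly a number 25 percentage points higher from compound 3 to compound 4 (beyond the scatter). Compound 4 is therefore estimated at 85%, likely between 65% and 100%.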

Compound 4, largest response reached (reported as percent of maximum), in percent of the reference or control that the assay uses: 102%
The estimate for compound 4 lay 17 percentage points below the measured number, and the stated range ends below it.
By their numbers in this assay, from the lowest: compound 3; then compound 2; then compounds 1 and 4 (each within the scatter of the next).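

In this assay cyclopropyl in place of hydroxymethyl gives a number 42 percentage points higher from compound 3 to compound 4 (beyond the scatter) and so restores a high number, while cyclopropyl in place of vinyl gives a number 23 percentage points higher from compound 2 to compound 4 (beyond the scatter) even though neither group carries oxygen, so losing the hydroxy group is not the whole story at this place. Cyclopropyl in place of methyl gives a number 6 percentage points higher from compound 1 to compound 4 (within the scatter) and shows that this place accepts a three-membered carbon ring. Nothing measured here explains these differences.

As far as these compounds go, whether a cyclobutyl ring, a longer chain such as propyl, or an amine would keep the number this high at this place remains open.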